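The source may report more compounds than this note shows. Statements on the series, on what has been measured and on what is new or still open speak of the compounds shown alone.

Measured compounds:
- compound 1 `COc1ccc(-c2nc(N=C(N)N)sc2-c2ccc(OC)cc2)cc1` — in a functional assay with Oryctolagus cuniculus as the target (a lower number here means a stronger inhibitor, a higher number a weaker inhibitor), compound 1 gives 31000 nM
- compound 2 `COc1ccc(-c2nc(/N=C(\N)n3ccnc3)sc2-c2ccc(OC)cc2)cc1` — in this assay compound 2 gives only a limit, > 100 nM

Within the data shown here, compound 1 is the only compound with a number in this assay. Compound 2 carries a limit rather than a number, as the limit of > 100 nM in this assay, at which 1 of the 2 values shown sits, records, and so the step that the limit leaves unreadable from compound 1 to compound 2 cannot be read.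

Compound 3 `COc1ccc(-c2nc(CNC(=O)c3cccnc3)sc2-c2ccc(OC)cc2)cc1` differs from compound 1 by a group of 10 heavy atoms (7 carbon, 2 nitrogen, 1 oxygen; one six-membered aromatic ring with 1 hetero atom) in place of a group of 4 heavy atoms (1 carbon, 3 nitrogen; no ring), on an aromatic carbon. Among the measured compounds shown here, no measured step bears on this change: the only step between measured compounds is unreadable, and it swaps the same group for a different one. What is expected in this assay therefore rests on compound 1 alone, with no direction to lean toward. The step of a 1.0-fold lower number from compound 1 to compound 3 (0.01 log units; within the scatter) is expected to stay within the scatter. Compound 3 is estimated at 30000 nM, with a range from 3000 nM to 150000 nM.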

Compound 3, half-maximal inhibitory concentration: 25 nM
Compound 3: the middle estimate sits 1200-fold (3.08 log units) above what was measured, and the stated range ends above it.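

In this assay, the group on this aromatic carbon, which lies next to the ring nitrogen and the ring sulfur, matters a great deal: placing (((pyridin-3-yl)carbonyl)amino)methyl there in place of the nitrogen-rich, ring-free group gives a 1200-fold lower number from compound 1 to compound 3 (3.09 log units; beyond the scatter). The same group also outdoes the one carrying a five-membered aromatic ring, giving an at least 4.0-fold lower number from compound 2 to compound 3 (0.60 log units; beyond the scatter). Compound 2 carries a limit and not a number, so that second step gives only a minimum size: the limit of > 100 nM in this assay, at which 1 of the 3 values shown sits.

The pyridin-3-yl ring, the carbonyl and the methyl link all enter together, so which of these parts accounts for the change stays open. Also open, from the compounds shown here alone, is how a plain phenyl ring in place of the pyridin-3-yl ring, a simple amine in place of the amide, or a longer chain would compare.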